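This account rests on a few compounds, and the source may have more. Where it says the series, first, only, none or still open, it means among the compounds named here.

Compound 1 `CCOC(=O)CN(C)C(=O)c1ccc(C(CC)(CC)c2ccc(OCC(=O)C(C)(C)C)c(C)c2)n1CC` carries an amide on the shared core. In an assay on HL-60 cells for agonist activity at vitamin D3 receptor (Homo sapiens), read by microscopy, with a stated time of 96 h (on this read-out higher numbers stand for an effect only at larger amounts of compound and lower numbers for an effect already at smaller amounts), compound 1 gives only a limit, > 50000 nM, and not a number. That value is the limit of > 50000 nM in this assay, at which 1 of the 3 values shown sits. The two measured neighbours are esters: compound 2 `C#CCCOC(=O)c1ccc(C(CC)(CC)c2ccc(OCC(O)C(C)(C)C)c(C)c2)n1CC` gives 1030 nM in this assay, and compound 3 `CCn1c(C(=O)Oc2ccc(CCO)cc2)ccc1C(CC)(CC)c1ccc(OCC(O)C(C)(C)C)c(C)c1` gives 5100 nM. Among the compounds with values here, the single measured step, a 5.0-fold higher number from compound 2 to compound 3 (0.69 log units; beyond the scatter), concerns only the group on the ester oxygen. Compound 4 `CCn1c(C(=O)OCc2ccccn2)ccc1C(CC)(CC)c1ccc(OCC(=O)C(C)(C)C)c(C)c1` is reached from compound 1 by a change at the carbonyl: (pyridin-2-yl)methoxy in place of ((ethoxycarbonyl)methyl)(methyl)amino on a carbonyl carbon. Within the data shown here, no measured step covers an amide becoming an ester, so the size of this step is not fixed by the data. Both esters, compound 2 and compound 3, give numbers in this assay. Compound 4 is therefore expected to give a number as well, estimated at 5000 nM, with a range from 1000 nM to 40000 nM. This estimate corresponds to an at least 10-fold lower number from compound 1 to compound 4 (1.00 log units; beyond the scatter), though a step from a limit cannot be sized exactly.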

Compound 4, half-maximal effective concentration: > 50000 nM
Compound 4 gave a limit, no number; the forecaster's own chance of this, stated with the estimate: 25%; middle value at least 10-fold (1.00 log units) from the limit.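

Compound 1 and compound 4 both give only a limit and not a number, so the step between them cannot be read: the limit of > 50000 nM in this assay, at which 2 of the 4 values shown sit.

The compounds shown leave open whether (pyridin-2-yl)methoxy in place of ((ethoxycarbonyl)methyl)(methyl)amino on a carbonyl carbon changes the read-out at all.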